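The source may report more compounds than this note shows. Statements on the series, on what has been measured and on what is new or still open speak of the compounds shown alone.

Measured in a functional assay on HL-60 cells (Homo sapiens) for inhibition, read by resazurin assay, with a stated time of 72 h; a higher number here means a weaker inhibitor, a lower number a stronger inhibitor:
- compound 1 `COc1cc(N2C(=O)CC2c2ccc(SC)cc2)cc(OC)c1OC` gives 69 nM
- compound 2 `C=CC1C(=O)N(c2cc(OC)c(OC)c(OC)c2)C1c1ccc(SC)cc1` gives 61 nM
- compound 3 `COc1ccc(C2C(C3CC3)C(=O)N2c2cc(OC)c(OC)c(OC)c2)cc1` gives 156 nM

Of these three, compound 3 has the highest number, which makes it the weakest inhibitor here. Compound 4 `COc1cc(N2C(=O)C(C3CC3)C2c2ccc(SC)cc2)cc(OC)c1OC` keeps the rest of compound 3 but has methylsulfanyl in place of methoxy on an aromatic carbon in a position para to a large group. Within the data shown here, no measured pair makes this exact swap. Among the measured compounds shown here, the only measured step, a 1.1-fold lower number from compound 1 to compound 2 (0.05 log units; within the scatter) for vinyl in place of hydrogen, is a different change. Still, compound 1 at 69 nM and compound 2 at 61 nM both carry methylsulfanyl, though they also differ from compound 3 elsewhere. A modest fall is therefore expected in this assay as the estimated step of a 2.1-fold lower number from compound 3 to compound 4 (0.32 log units; beyond the scatter) near the edge of the scatter. For compound 4 the expected value is 75 nM within an estimated range from 30 nM to 180 nM overall.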

Compound 4, half-maximal inhibitory concentration: 279 nM
Compound 4: the middle estimate sits 3.7-fold (0.57 log units) below what was measured; measured number outside the range, above it.
By their numbers in this assay, from the lowest: compounds 2 and 1 (each within the scatter of the next); then compounds 3 and 4 (each within the scatter of the next).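

In this assay, the swap to 4-(methylsulfanyl)phenyl from 4-methoxyphenyl gives a 1.8-fold higher number from compound 3 to compound 4 (0.25 log units; within the scatter), so with cyclopropyl on the saturated ring carbon these two groups cannot be told apart. With methylsulfanyl held in place, that ring carbon matters more: cyclopropyl in place of hydrogen gives a 4.0-fold higher number from compound 1 to compound 4 (0.61 log units; beyond the scatter) and cyclopropyl in place of vinyl gives a 4.6-fold higher number from compound 2 to compound 4 (0.66 log units; beyond the scatter). No measurement here explains these steps.

Still open, on these data alone, is whether the swap reads the same with hydrogen or vinyl on that carbon, and how an amine or a longer chain there would compare.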